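The source may report more compounds than this note shows. Statements on the series, on what has been measured and on what is new or still open speak of the compounds shown alone.

Compound 1 `CC(c1cc2cccnc2cc1F)n1cnc2ncc(-c3cnn(C)c3)nc21`: 9 uL/min
Compound 2 `CC(c1c(F)cc2ncccc2c1F)n1cnc2ncc(-c3cnn(C)c3)nc21`: 11 uL/min
Compound 3 `CC(c1c(F)cc2ncccc2c1F)n1cnc2ncc(-c3cnn(CCO)c3)nc21`: 2 uL/min

All three were measured in an ADME assay on microsomes from liver (Homo sapiens) for metabolic stability, read by LC-MS, using NADPH, with stated times of 5 min and 30 min, tested at 1 uM; a higher number here means faster removal of the compound, a lower number slower removal. Compound 3 stands lowest of the three, with compound 1 nearest and compound 2 furthest, both beyond the scatter. Compound 4 `CC(c1c(F)cc2ncccc2c1F)n1cnc2ncc(-c3ccncc3)nc21` has not been measured; it differs from compound 3 by pyridin-4-yl in place of 1-(2-hydroxyethyl)-1H-pyrazol-4-yl on an aromatic carbon. Within the data shown here, the only measured step bearing on the group at that place is a 5.5-fold lower number from compound 2 to compound 3 (0.74 log units; beyond the scatter), where the hydroxymethyl entered; the step of a 1.2-fold higher number from compound 1 to compound 2 (0.09 log units; within the scatter) concerns a fluoro elsewhere and lies within the scatter. Compound 4 carries no hydroxyl, so the expected step of a 4.5-fold higher number from compound 3 to compound 4 (0.65 log units; beyond the scatter) is a rise, back toward the numbers seen for compounds 1 and 2. Compound 4 is therefore estimated at 9 uL/min, with a range from 4 uL/min to 20 uL/min.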

Compound 4, intrinsic clearance in a liver preparation (reported as CLH), per the amount of preparation that the assay uses: 14 uL/min
Estimate against measurement, compound 4: 1.6-fold (0.19 log units) below; the measured number falls inside the stated range.
By their numbers in this assay, from the lowest: compound 3; then compounds 1, 2 and 4 (each within the scatter of the next).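

In this assay, pyridin-4-yl in place of 1-(2-hydroxyethyl)-1H-pyrazol-4-yl gives a 7.0-fold higher number from compound 3 to compound 4 (0.85 log units; beyond the scatter), whereas pyridin-4-yl in place of 1-methyl-1H-pyrazol-4-yl gives only a 1.3-fold higher number from compound 2 to compound 4 (0.10 log units; within the scatter), which lies within the scatter. At this place, then, the six-membered ring and the methylated five-membered ring cannot be told apart, and of the three groups only 1-(2-hydroxyethyl)-1H-pyrazol-4-yl stands apart. Nothing available gives a reason for this difference. From the compounds shown here alone, it remains open whether a hydroxyethyl chain on pyridin-4-yl would also lower the number, and how an amine or a carboxylic acid at the end of the chain on the 1H-pyrazol-4-yl would read.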